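The source may report more compounds than this note shows. Statements on the series, on what has been measured and on what is new or still open speak of the compounds shown alone.

The series under study here is a small set of positive allosteric modulators tested in a functional assay on the whole organism for positive allosteric modulation, with Rattus norvegicus as the target; on this read-out higher numbers stand for an effect only at larger amounts of compound and lower numbers for an effect already at smaller amounts. Compound 1, `Cc1nn(C)c2c1C(c1ccccc1Cl)=NCCN2C`, gives 2.5 mg/kg in this assay. Compound 2, `CCn1nc(C)c2c1N(C)CCN=C2c1ccccc1Cl`, differs from compound 1 by methyl in place of hydrogen on a saturated chain carbon bound to an aromatic nitrogen; in this assay compound 2 gives 5 mg/kg, and the change made a 2.0-fold higher number from compound 1 to compound 2 (0.30 log units; within the scatter). Compound 3, `Cc1nn(C)c2c1C(c1cccc(C(F)(F)F)c1)=NCCN2`, carries a trifluoromethyl group in place of the chloro substituent of compound 1, though the difference between the two cores is not broken down here; in this assay compound 3 gives 0.63 mg/kg, the lowest of the three numbers, and its steps to compound 1 and to compound 2 both lie beyond the scatter.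

Compound 4, `CCn1nc(C)c2c1NCCN=C2c1cccc(C(F)(F)F)c1`, has not yet been measured. It differs from compound 3 by methyl in place of hydrogen on a saturated chain carbon bound to an aromatic nitrogen, the same change that leads from compound 1 to compound 2. Among the measured compounds shown here, since that earlier change yielded only a 2.0-fold higher number from compound 1 to compound 2 (0.30 log units; within the scatter), a step that did not leave the usual scatter, the expectation for compound 4 is a step of about a 2.0-fold higher number from compound 3 to compound 4 (0.30 log units; within the scatter) in this assay, resting on the one precedent in the pair compound 1 and compound 2. For the measured compounds named here, compound 4 is therefore estimated to give 1.25 mg/kg in this assay, with a range from 0.5 mg/kg to 3.2 mg/kg allowing for the scatter of this kind of measurement and the single example on which the expectation rests.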

Compound 4, minimum effective dose: 0.63 mg/kg
Compound 4: middle estimate off by 2.0-fold (0.30 log units), on the high side; measured number inside the range.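

Carried over to the core of compound 3, the replacement of hydrogen by methyl on a saturated chain carbon bound to an aromatic nitrogen, which turns methyl into ethyl, gave no change at the digits printed from compound 3 to compound 4 (within the scatter) in this assay. Set beside the step on the core of compound 1, the result agrees with it, and the two cores give no sign of treating this change differently: the same change on two cores in this assay, a 2.0-fold higher number (0.30 log units; within the scatter) from compound 1 to compound 2 and no change at the digits printed (within the scatter) from compound 3 to compound 4, 2.0-fold (0.30 log units) apart, within the scatter of two such steps. Among the compounds shown here, this shows that in these two pairs the change carried over without a step beyond the scatter, but with only two pairs, each within the scatter, it neither fixes a size for the step nor shows that the step would stay as small on any other core.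

The compounds shown leave open what a longer chain such as propyl, a branched chain such as isopropyl, or a chain ending in an amine or a carboxylic acid would give at this same place. They also leave open whether the change from methyl to ethyl would carry over as it did here if a nitrile or a methoxy group stood in place of the chloro or trifluoromethyl substituent.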